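The source may report more compounds than this note shows. Statements on the series, on what has been measured and on what is new or still open speak of the compounds shown alone.

Compound 3 `CCN(CC)CCCNc1nc(-c2ccc(NC(=O)Nc3ccc(F)cc3)cc2)nc2c(Cl)c(Cl)sc12` stands at the low end of the three numbers in a functional assay on HT-29 cells (Homo sapiens) for cytotoxicity, read by MTT assay, with a stated time of 72 h (on this read-out higher numbers stand for weaker inhibition and lower numbers for stronger inhibition), giving 350 nM, though compound 1 `CN(C)CCCNc1nc(-c2ccc(NC(=O)Nc3ccc(F)cc3)cc2)nc2c(Cl)c(Cl)sc12` with 430 nM lies within the scatter of it; compound 2 `CN(C)CCNc1nc(-c2ccc(NC(=O)Nc3ccc(F)cc3)cc2)nc2c(Cl)c(Cl)sc12` gives 890 nM. The step of a 1.2-fold lower number from compound 1 to compound 3 (0.09 log units; within the scatter) is within the scatter, whereas a 2.1-fold higher number from compound 1 to compound 2 (0.32 log units; beyond the scatter) and a 2.5-fold lower number from compound 2 to compound 3 (0.41 log units; beyond the scatter) are beyond it. Compound 4 `CCN(CC)CCNc1nc(-c2ccc(NC(=O)Nc3ccc(F)cc3)cc2)nc2c(Cl)c(Cl)sc12` differs from compound 3 by diethylamino in place of (diethylamino)methyl on a saturated chain carbon, two bonds along the chain from a nitrogen on an aromatic ring. The same change has been measured once in the dimethyl pair, as a 2.1-fold higher number from compound 1 to compound 2 (0.32 log units; beyond the scatter), a modest rise in the number. A step of similar size and the same direction is therefore expected, a 2.1-fold higher number from compound 3 to compound 4 (0.33 log units; beyond the scatter). The estimated value for compound 4 in this assay is 750 nM, with a range from 350 nM to 1600 nM.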

Compound 4, half-maximal inhibitory concentration: 650 nM
The estimate for compound 4 lay 1.2-fold (0.06 log units) above the measured number; low and high end bracket the measured number.
By their numbers in this assay, from the lowest: compounds 3, 1, 4 and 2 (each within the scatter of the next, the first and the last beyond it).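

Replacing (diethylamino)methyl with diethylamino gives a 1.9-fold higher number from compound 3 to compound 4 (0.27 log units; within the scatter), so this chain shortening does not clear the scatter with diethylamino, unlike the step with dimethylamino. The step of a 1.5-fold higher number from compound 1 to compound 4 (0.18 log units; within the scatter) also stays within the scatter. On the shorter chain, a 1.4-fold lower number from compound 2 to compound 4 (0.14 log units; within the scatter), so the exchange of dimethylamino for diethylamino now reads alike on both chains: the same change on two cores in this assay, a 1.2-fold lower number (0.09 log units; within the scatter) from compound 1 to compound 3 and a 1.4-fold lower number (0.14 log units; within the scatter) from compound 2 to compound 4, 1.1-fold (0.05 log units) apart, within the scatter of two such steps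

Still open, as far as these compounds go, are a longer chain, such as 4-(diethylamino)butyl, and a ring amine, such as morpholine, in place of diethylamino.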